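Trimethoxyphenyl in place of chlorophenyl on a chalcone-bearing core

A few compounds are considered here, and "the series" means these few. Any claim that something is new, unique, unknown or untested is made for them only; others in the source may bear on it.

Of the compounds shown here, two have been tested in a functional assay on RPMI8266 cells (Homo sapiens) for inhibition; on this read-out lower numbers stand for stronger inhibition of growth and higher numbers for weaker inhibition of growth. Compound 1 `COc1cc(/C=C/C(=O)c2cccc(-n3cc(-c4ccc(Cl)cc4)[nH]c3=O)c2)cc(OC)c1OC` gives 3920 nM in this assay, the highest of the two numbers and hence the weaker growth inhibitor; compound 2 `COc1ccc(-c2cn(-c3cccc(C(=O)/C=C/c4ccc(O)c(OC)c4)c3)c(=O)[nH]2)cc1` gives 1350 nM in this assay, a lower number that lies beyond the scatter of the two values. Compound 2 differs from compound 1 in more than one place, so its values show only where the two compounds stand and not what any single change does.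

Compound 3 `COc1cc(/C=C/C(=O)c2cccc(-n3cc(-c4cc(OC)c(OC)c(OC)c4)[nH]c3=O)c2)cc(OC)c1OC` has not yet been measured. It arises from compound 1 by a single change: 3,4,5-trimethoxyphenyl in place of 4-chlorophenyl on an aromatic carbon. Among the measured compounds shown here, no measured pair isolates this change, so the expectation rests on compound 1 alone. Compound 3 is expected to give 2000 nM in this assay, within a range from 700 nM to 6000 nM. The estimated step of a 2.0-fold lower number from compound 1 to compound 3 (0.29 log units; within the scatter) is thus a moderate move toward stronger inhibition, though one that may fall within the scatter.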

Compound 3, concentration for 50% growth inhibition: 230 nM
For compound 3 the middle estimate is 8.7-fold (0.94 log units) above the measured one; measured number below the stated range.
By their numbers in this assay, from the lowest: compound 3; then compound 2; then compound 1.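

The aryl group on this aromatic carbon of the five-membered aromatic ring turns out to matter strongly for growth inhibition: in this assay, 3,4,5-trimethoxyphenyl in place of 4-chlorophenyl gives a 17-fold lower number from compound 1 to compound 3 (1.23 log units; beyond the scatter), with the rest of the molecule unchanged. Compound 1 and compound 2 differ in more than one place and could not assign any effect to this position, whereas this single change does so and makes it a large effect. The data available offer no measurement that explains the size of this step.

As far as these compounds go, whether all three methoxy groups are needed remains open, as a 3,4-dimethoxyphenyl or 3,5-dimethoxyphenyl group at the same carbon would show. From the compounds shown here alone, it is equally open whether the step carries over to a core with a different group on the chalcone end, such as the 4-hydroxy-3-methoxyphenyl of compound 2.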